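Shortening a Side Chain on a Weak Analogue

The source may hold more compounds than are shown below. What is called first, only, known or untested is meant among the compounds shown, and "the series" means these compounds.

Among the compounds with values here, the three compounds measured so far share one core, and the spread among them is wide. Compound 1 `COc1ccc(N(C)c2nc(C)nc3ccccc23)cc1C(=O)OCCC[Se]C#N` gives 854 nM in a functional assay on LoVo cells (Homo sapiens) for inhibition, read by MTT assay, with a stated time of 48 h (a lower number here means a stronger inhibitor, a higher number a weaker inhibitor), the highest number of the three. Compound 2 `C[Se]c1ccc(N(C)c2nc(C3CC3)nc3ccccc23)cc1` gives 11 nM, and compound 3 `Cc1nc(N(C)c2ccc([Se]C#N)c(F)c2)c2ccccc2n1` gives 13 nM. Both of these stand far below compound 1, and both gaps lie beyond the usual scatter, so compound 1 is plainly the weakest of the set on these numbers.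

The next compound, compound 4 `COc1ccc(N(C)c2nc(C)nc3ccccc23)cc1OCC[Se]C#N`, differs from compound 1 in one place only: a group of 6 heavy atoms (3 carbon, 1 nitrogen, 1 oxygen, 1 selenium; no ring) in place of a group of 9 heavy atoms (5 carbon, 1 nitrogen, 2 oxygen, 1 selenium; no ring), on an aromatic carbon The change sits on an aromatic carbon of the six-membered ring of carbon only, ortho to the methoxy group and meta to the large group. A group of 9 heavy atoms with a double bond and a triple bond leaves, and a group of 6 heavy atoms with a triple bond enters.

Within the data shown here, no measured pair reports a step of this kind, so the direction rests only on the three values shown. Compound 1 is expected to improve somewhat toward the two potent compounds, with the step from compound 1 to compound 4 estimated at a 1.9-fold lower number from compound 1 to compound 4 (0.28 log units; within the scatter). Compound 4 is therefore expected to give about 450 nM, within a range of 120 nM to 1700 nM.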

Compound 4, half-maximal inhibitory concentration: 19 nM
Estimate against measurement, compound 4: 24-fold (1.37 log units) above, outside the stated range (below it).
By their numbers in this assay, from the lowest: compounds 2, 3 and 4 (each within the scatter of the next); then compound 1.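

In this assay, placing the group of 6 heavy atoms on this aromatic carbon, ortho to a methoxy group, in place of the group of 9 heavy atoms gives a 45-fold lower number from compound 1 to compound 4 (1.65 log units; beyond the scatter), a large step. Within the data shown here, the earlier compounds offered no pair differing in one place, so this is the first direct reading of a single change, and it shows that the high value of compound 1 (854 nM) depends strongly on this one side chain, with the rest of the molecule unchanged. The two groups differ at once in size, in the double bond and in hydrogen-bond acceptors, so this single step cannot separate those differences, and no measurement at hand explains the step.

From the compounds shown here alone, it remains open whether the shorter chain or the loss of the ester link accounts for the step, and an ester with a shorter chain or an ether with a longer chain would help separate the two. The compounds shown also leave open how this position would respond to an amine or a carboxylic acid at the end of the chain in place of the selenocyanate end.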